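The compounds below may be only part of what the source reports. "The series", "measured", "known", "first", "only" and "open" are said of these compounds alone.

Measured compounds:
compound 1 `COc1cc(-c2nccn3cc(-c4ccc(Cl)cc4)nc23)cc(OC)c1OC` — 475 nM
compound 2 `COc1cc(-c2nccn3cc(-c4ccc5[nH]ccc5c4)nc23)cc(OC)c1OC` — 146 nM
compound 3 `COc1cc(-c2nccn3cc(-c4ccc([N+](=O)[O-])cc4)nc23)cc(OC)c1OC` — a limit, > 10000 nM

In a functional assay on HepG2 cells (Homo sapiens) for inhibition, read by MTT assay, with a stated time of 48 h (on this read-out lower numbers stand for stronger inhibition and higher numbers for weaker inhibition), compound 1 gives 475 nM, the higher of the two numbers recorded; the step of a 3.3-fold lower number from compound 1 to compound 2 (0.51 log units; beyond the scatter) is the nearest comparison. Compound 3 sits at the limit of > 10000 nM in this assay, at which 1 of the 3 values shown sits, and supplies no number.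

Compound 4 `COc1cc(-c2nccn3cc(-c4ccc(C)cc4)nc23)cc(OC)c1OC` differs from compound 1 by methyl in place of chloro on an aromatic carbon. Among the measured compounds shown here, no measured step exchanges chloro for methyl. The measured steps bearing on the same position are an at least 21-fold higher number from compound 1 to compound 3 (1.32 log units; beyond the scatter) and an at least 68-fold higher number from compound 2 to compound 3 (1.83 log units; beyond the scatter), both large; the nitro group stands alone in producing them, and methyl shares none of its features. For compound 4 in this assay no step beyond the scatter is therefore expected. Compound 4 is estimated at 600 nM, range 200 nM to 2000 nM, an expected step of a 1.3-fold higher number from compound 1 to compound 4 (0.10 log units; within the scatter).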

Compound 4, half-maximal inhibitory concentration: 160 nM
Compound 4: middle estimate off by 3.8-fold (0.57 log units), on the high side, and the stated range ends above it.
By their numbers in this assay, from the lowest: compounds 2 and 4 (each within the scatter of the next); then compound 1. At a limit, above all of these: compound 3.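

In this assay, this place on the six-membered aromatic ring proves sensitive to more than the nitro exchange, since swapping chloro for methyl, one heavy atom for one, gives a 3.0-fold lower number from compound 1 to compound 4 (0.47 log units; beyond the scatter). A simple 4-methylphenyl also matches the 1H-indol-5-yl group, with a 1.1-fold higher number from compound 2 to compound 4 (0.04 log units; within the scatter). The nitro value is a limit, so an at least 62-fold lower number from compound 3 to compound 4 (1.79 log units; beyond the scatter) is a bound and not a measured size: the limit of > 10000 nM in this assay, at which 1 of the 4 values shown sits.

As far as these compounds go, whether an amine, a methoxy group or a longer chain at this place tracks methyl, chloro or nitro remains open. From the compounds shown here alone, whether methyl's gain over chloro holds on other cell lines also remains open.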